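The compounds below may be only part of what the source reports. "The series", "measured", "known", "first", "only" and "open" are said of these compounds alone.

Measured so far: compound 1 `COc1ncc(C(F)(F)F)cc1CO[C@H]1[C@H](C(C)(C)C)[C@@H](C(=O)O)N(C(=O)C2CCCCC2)[C@H]1c1ccccc1` with 650% in an assay on cells with Cystic fibrosis transmembrane conductance regulator variant F508del (Homo sapiens) as the target, read by voltage clamp, with a stated time of 24 h, in the presence of a further agent that is not named here; a lower number here means a smaller maximal response, a higher number a larger maximal response; compound 2 `COc1ncc(C(F)(F)F)cc1CO[C@H]1[C@H](C(C)(C)C)[C@@H](C(=O)O)N(C(=O)[C@@H]2CCCCO2)[C@H]1c1ccccc1` with 720% in the same assay.

Among the measured compounds shown here, compound 2 holds the higher of the two numbers; its nearest neighbour is compound 1, and the single measured step, a number 70 percentage points higher from compound 1 to compound 2 (beyond the scatter), lies beyond the scatter. Compound 3 `COc1ncc(C(F)(F)F)cc1CO[C@H]1[C@H](C(C)(C)C)[C@@H](C(=O)O)N(C(=O)[C@H]2CCCCO2)[C@H]1c1ccccc1` is the unmeasured partner. How 3 differs from 2: the two compounds have the same atoms and bonds and differ only in configuration as drawn: 1 of 5 stereo elements differ; a stereocentre at a saturated ring carbon is drawn S in compound 2 and R in compound 3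

For the measured compounds named here, no measured step bears directly on this change: the only step in hand exchanges cyclohexyl for oxan-2-yl, and nothing on file shows what turning the stereocentre at the saturated ring carbon does. The step from compound 1 to compound 2 is therefore only a reminder that alterations at this carbonyl substituent can move the largest response by a good margin. For compound 3 the expected step is a number 80 percentage points lower from compound 2 to compound 3 (beyond the scatter), with the direction open. Compound 3 is estimated at 640%, range 450% to 800%.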

Compound 3, largest response reached (Emax), in percent of the reference or control that the assay uses: 351%
Estimate against measurement, compound 3: 289 percentage points above; measured number below the stated range.
By their numbers in this assay, from the lowest: compound 3; then compound 1; then compound 2.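

In this assay, the drawn configuration at the saturated ring carbon of the oxan-2-yl group proves decisive, with a number 369 percentage points lower from compound 2 to compound 3 (beyond the scatter). This large step is tied to a single stereocentre: the fact that compounds 2 and 3 differ only in the configuration as drawn

The exchange of cyclohexyl for oxan-2-yl on the carbonyl carbon therefore has no single outcome in this small set: the S form gives a number 70 percentage points higher from compound 1 to compound 2 (beyond the scatter), whereas the R form gives a number 299 percentage points lower from compound 1 to compound 3 (beyond the scatter).

The compounds shown leave open whether a similar dependence on configuration would appear with another ring on this carbonyl, such as a morpholine or a tetrahydrofuran. What underlies the gap between the two configurations also remains unresolved, as the data give no measured basis for it.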